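The compounds below may be only part of what the source reports. "The series", "measured", "known", "first", "only" and "open" are said of these compounds alone.

Measured in a functional assay on HeLa cells (Homo sapiens) for antiproliferative activity, read by MTT assay, with a stated time of 72 h; on this read-out lower numbers stand for stronger inhibition and higher numbers for weaker inhibition:
- compound 1 `Nc1nc(N)c2cc(CSC(=S)N3CCN(c4ccc(O)cc4)CC3)ccc2n1`: 5180 nM
- compound 2 `Nc1nc(N)c2cc(CSC(=S)N3CCN(c4ccc(F)cc4)CC3)ccc2n1`: 1840 nM
- compound 3 `Nc1nc(N)c2cc(CSC(=S)N3CCN(c4ccccc4F)CC3)ccc2n1`: 6660 nM

In this assay compound 3 gives 6660 nM. This matches compound 1 within the scatter, as shown by a 1.3-fold higher number from compound 1 to compound 3 (0.11 log units; within the scatter). Compound 2 stands clearly apart, with a 3.6-fold higher number from compound 2 to compound 3 (0.56 log units; beyond the scatter).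

Compound 4 `Nc1nc(N)c2cc(CSC(=S)N3CCN(c4ccc(F)cc4F)CC3)ccc2n1` has not yet been measured. It carries 2,4-difluorophenyl where compound 3 has 2-fluorophenyl: fluoro in place of hydrogen on an aromatic carbon. In words, this is fluoro in place of hydrogen on an aromatic carbon, para to a large group and meta to a fluoro group.

For the measured compounds named here, no measured compound has two fluoro groups, so the evidence is indirect. The closest guide is a 3.6-fold higher number from compound 2 to compound 3 (0.56 log units; beyond the scatter), which shows that the 4-fluorophenyl compound has the lower number of that pair. A second modest step, a 2.8-fold lower number from compound 1 to compound 2 (0.45 log units; beyond the scatter), also leads to compound 2. Compound 4 keeps the 2-fluorophenyl feature of compound 3 and gains the fluoro found at the para place in compound 2, so it may fall between those two values.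

The expected change is a 2.1-fold lower number from compound 3 to compound 4 (0.32 log units; beyond the scatter), a modest step towards stronger inhibition. For compound 4 the estimated value is 3200 nM, with an expected range of 1300 nM to 7500 nM.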

Compound 4, half-maximal inhibitory concentration: 3800 nM
Compound 4: middle estimate off by 1.2-fold (0.07 log units), on the low side; the measured number falls inside the stated range.
By their numbers in this assay, from the lowest: compound 2; then compounds 4, 1 and 3 (each within the scatter of the next).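

Adding fluoro to the 2-fluorophenyl ring of compound 3 gives a 1.8-fold lower number from compound 3 to compound 4 (0.24 log units; within the scatter) in this assay, so this second fluoro, para to a large group and meta to a fluoro group, brings no change that can be told from ordinary assay noise. Compound 4 differs from the 4-fluorophenyl compound by one added fluoro, with a 2.1-fold higher number from compound 2 to compound 4 (0.31 log units; beyond the scatter) showing that the 2,4-difluorophenyl ring does not match the lowest number in the set, while a 1.4-fold lower number from compound 1 to compound 4 (0.13 log units; within the scatter) leaves compound 4 indistinguishable from the 4-hydroxyphenyl compound. The earlier compounds showed the two single-fluoro rings apart, and the new result adds that combining both fluoro groups gives a number clearly separate only from that of compound 2, although nothing measured here explains why.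

The compounds shown leave open whether a chloro or methoxy group at this same ring place would behave like fluoro or hydroxy. For the compounds shown here, they also leave open how a ring with no substituent at all, a plain phenyl, would compare, which would show what the single fluoro groups contribute on their own.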